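Methoxy in place of trifluoromethyl in compound 4

A few compounds are considered here, and "the series" means these few. Any claim that something is new, unique, unknown or untested is made for them only; others in the source may bear on it.

In a physicochemical assay for solubility, in phosphate buffer, measured as kinetic solubility, at pH 7.4 (on this read-out higher numbers stand for higher solubility and lower numbers for lower solubility), compound 1 `Cc1ccc(C)c(-c2nc(CN3CCC(C(=O)NCCCN4C[C@H](C)C[C@H](C)C4)CC3)c(C)o2)c1` gives 56.1 ug/mL and compound 3 `Cc1oc(-c2c(Cl)cccc2C(F)(F)F)nc1CN1CCC(C(=O)NCCCN2C[C@H](C)C[C@H](C)C2)CC1` gives 65.1 ug/mL as a value within the scatter of the first. Compound 2 `Cc1oc(-c2ccccc2Cl)nc1CN1CCC(C(=O)NCCCN2C[C@H](C)C[C@H](C)C2)CC1` reads > 72 ug/mL as a limit of the assay and not a number. Compound 3 therefore stands level with compound 1 among the actual numbers.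

Compound 4 `COc1cccc(Cl)c1-c1nc(CN2CCC(C(=O)NCCCN3C[C@H](C)C[C@H](C)C3)CC2)c(C)o1` is still unmeasured. It differs from compound 3 by methoxy in place of trifluoromethyl on an aromatic carbon with methoxy in place of trifluoromethyl on an aromatic carbon, ortho to a large group and meta to a chloro group.

The closest measured change is an at least 1.1-fold lower number from compound 2 to compound 3 (0.04 log units; that floor lies within the scatter) for trifluoromethyl in place of hydrogen on an aromatic carbon. Changes of the whole substituted phenyl gave an at least 1.2-fold higher number from compound 1 to compound 2 (0.10 log units; that floor lies within the scatter) and a 1.2-fold higher number from compound 1 to compound 3 (0.06 log units; within the scatter) as the other two steps. On the strength of a 1.2-fold higher number from compound 1 to compound 3 (0.06 log units; within the scatter) no step beyond the scatter is expected in this assay for this exchange. The estimated step is a 1.0-fold higher number from compound 3 to compound 4 (0.01 log units; within the scatter) and it carries no firm direction. For compound 4 the expected value is 66 ug/mL with an estimated range from 40 ug/mL to 85 ug/mL once measured.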

Compound 4, solubility: > 76 ug/mL
Compound 4 gave a limit, no number; the forecaster's own chance of this, stated with the estimate: 35%; middle value at least 1.1-fold (0.06 log units) away from the limit.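

Compound 4 is a limit of the assay and not a number, in this assay: the limit of > 76 ug/mL in this assay, at which 1 of the 4 values shown sits.

With methoxy, which brings a hydrogen-bond acceptor to the position ortho to a large group, the step reads an at least 1.1-fold higher number from compound 3 to compound 4 (0.06 log units; that floor lies within the scatter), so the exchange of trifluoromethyl shows no drop on this read-out, and the 2-chloro-6-methoxyphenyl group sits in the same way against the 2,5-dimethylphenyl group, with an at least 1.3-fold higher number from compound 1 to compound 4 (0.13 log units; that floor lies within the scatter). Compound 2 and compound 4 are both limits, and the step between them cannot be read.

Any real gain from methoxy stays open, since only floors within the scatter are available and compound 4 has no actual number. Going by these compounds, how an amine, a carboxylic acid or a longer alkoxy chain would read at this position also stays open.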